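The source may report more compounds than this note shows. Statements on the series, on what has been measured and on what is new or still open speak of the compounds shown alone.

Compound 1 `O=C(CSc1nc2ccccc2s1)N/N=C/c1c[nH]c2ccccc12` and compound 2 `C/C(=N\NC(=O)c1ccc(CSc2nc3ccccc3s2)cc1)c1ccc(C)c([N+](=O)[O-])c1` share a hydrazone-linked core with compound 3 `C/C(=N\NC(=O)c1ccc(CSc2nc(C)cc(C)n2)cc1)c1ccc(F)cc1`. In a functional assay on HepG2 cells (Homo sapiens) for inhibition, read by MTT assay, with a stated time of 72 h (a higher number here means a weaker inhibitor, a lower number a stronger inhibitor), compound 1 gives only a limit, > 80 ug/mL. Compound 2 likewise gives only a limit in this assay, > 80 ug/mL. Among the measured compounds shown here, compound 3, with a dimethylpyrimidine thioether and a 4-fluorophenyl group, is the one compound of the three with a measured number, giving 4.85 ug/mL in this assay, the other two sitting at the limit of > 80 ug/mL in this assay, at which 2 of the 3 values shown sit. Compound 4 `C/C(=N\NC(=O)c1ccc(CSc2nc(C)cc(C)n2)cc1)c1ccc(C)c([N+](=O)[O-])c1` is not yet measured; it differs from compound 3 by 4-methyl-3-nitrophenyl in place of 4-fluorophenyl on a carbon with a double bond to nitrogen. Compound 2 carries the same 4-methyl-3-nitrophenyl group and gives only a limit, so a loss of potency beyond the scatter is expected, a 4.1-fold higher number from compound 3 to compound 4 (0.62 log units; beyond the scatter). Compound 4 is estimated at 20 ug/mL, within 5 ug/mL to 80 ug/mL.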

Compound 4, half-maximal inhibitory concentration: > 80 ug/mL
Compound 4: no number, only a limit (the forecaster's own chance of this, stated with the estimate: 40%); at least 4.0-fold (0.60 log units) between middle value and limit.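

Among the compounds shown here, the change from 4-fluorophenyl to 4-methyl-3-nitrophenyl on a carbon with a double bond to nitrogen is the first single change that can be read in this assay, and it gives an at least 16-fold higher number from compound 3 to compound 4 (1.21 log units; beyond the scatter). The 4,6-dimethylpyrimidin-2-yl group on the sulfur therefore does not secure a measured number alone, and compound 4 ends at a limit: the limit of > 80 ug/mL in this assay, at which 3 of the 4 values shown sit. The step between the two limit compounds that differ on the sulfur cannot be read.

Whether the nitro group or the methyl group accounts for the loss remains open. So does whether a 4-chlorophenyl or 4-aminophenyl group on this carbon would give a measured number.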